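This account rests on a few compounds, and the source may have more. Where it says the series, first, only, none or still open, it means among the compounds named here.

Compound 1, `CC/N=C(/NC#N)NCCCCCn1nc(-c2ccccc2)ccc1=O`, gives 60.3 mg/kg in a functional assay on the whole organism with Rattus norvegicus as the target; a lower number here means that less compound is needed, a higher number that more compound is needed for the effect.
Compound 2, `CC/N=C(\S)NCCCn1nc(-c2ccccc2)ccc1=O`, gives 88.2 mg/kg in this assay.
Compound 3, `C/N=C(/NC#N)NCCCn1nc(-c2ccccc2)ccc1=O`, gives 78.1 mg/kg in this assay.

The three measured numbers lie close together, and compound 3 sits among them: its difference from compound 2 and from compound 1 each stays within the scatter, so no ordering among them is claimed. Compound 4, `C=CCNC(=S)NCCCCn1nc(-c2ccccc2)ccc1=O`, is reached from compound 3 by a group of 8 heavy atoms (5 carbon, 2 nitrogen, 1 sulfur; no ring) in place of a group of 7 heavy atoms (3 carbon, 4 nitrogen; no ring), on a saturated chain carbon, three bonds along the chain from an aromatic nitrogen. Within the data shown here, the one measured step that bears on this is the exchange of the thiourea for the cyanoguanidine on the amine nitrogen, a 1.1-fold lower number from compound 2 to compound 3 (0.05 log units; within the scatter), which did nothing beyond the scatter; compound 4 moves back to a thiourea, on a chain one carbon longer and with an allyl in place of the methyl. Compound 1 and compound 3, which differ in chain length, also show numbers within the scatter of each other. Compound 4 is therefore expected to show a 1.0-fold lower number from compound 3 to compound 4 (0.02 log units; within the scatter), nothing beyond the scatter. The estimate for compound 4 in this assay is 75 mg/kg, with a range from 35 mg/kg to 160 mg/kg.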

Compound 4, dose for half-maximal effect: 78.6 mg/kg
For compound 4 the middle estimate is 1.0-fold (0.02 log units) below the measured one; measured number inside the range.
By their numbers in this assay, from the lowest: compounds 1, 3, 4 and 2 (each within the scatter of the next).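

In this assay, the group with the allyl and the thiourea, placed on a saturated chain carbon, three bonds along the chain from an aromatic nitrogen, gives a 1.0-fold higher number from compound 3 to compound 4 (0.00 log units; within the scatter) when it replaces the cyanoguanidine group, and a 1.1-fold lower number from compound 2 to compound 4 (0.05 log units; within the scatter) when it replaces the thiourea group of compound 2. Earlier, only the exchange on the amine nitrogen had been followed as a single step; now a change that alters the end group and the chain together also stays within the scatter. Nothing available explains why the numbers stay so close. Going by these compounds, whether a benzyl in place of the allyl, a urea in place of the thiourea, or a carboxylic acid at the chain end would separate from these numbers stays open. So does the effect of the allyl alone, apart from the chain.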